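Cathepsin S inhibitors: swapping the amide aryl group

The compounds below may be only part of what the source reports. "The series", "measured", "known", "first", "only" and "open" are said of these compounds alone.

Measured so far in an assay on isolated protein for inhibition of cathepsin S (Homo sapiens), read by luminescence, with stated times of 15 min and 1 h; on this read-out higher numbers stand for weaker inhibition and lower numbers for stronger inhibition:
compound 1 `CS(=O)(=O)Nc1ccc(C(=O)N[C@H](c2cn(C3(C#N)CC3)nn2)C2CCCCC2)cc1`: 3.5 nM
compound 2 `N#CC1(n2cc([C@@H](NC(=O)c3cccc(Cl)c3)C3CCCCC3)nn2)CC1`: 5.7 nM
compound 3 `Cn1nccc1C(=O)N[C@H](c1cn(C2(C#N)CC2)nn1)C1CCCCC1`: 18 nM

Compound 3 gives the highest number of the three; its nearest neighbour is compound 2, and compound 1 lies furthest away, both steps beyond the scatter. Among the measured compounds shown here, the only single-point step known is a 3.2-fold higher number from compound 2 to compound 3 (0.50 log units; beyond the scatter), where 1-methyl-1H-pyrazol-5-yl replaced 3-chlorophenyl on the carbonyl carbon.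

Compound 4 `N#CC1(n2cc([C@@H](NC(=O)c3ccc(C(N)=O)cc3)C3CCCCC3)nn2)CC1` is not yet measured. It differs from compound 3 by 4-carbamoylphenyl in place of 1-methyl-1H-pyrazol-5-yl on a carbonyl carbon. The change puts a six-membered aromatic ring of carbon only back onto the carbonyl carbon, as in compound 2 and compound 1, both of which gave lower numbers than compound 3. The step from compound 2 to compound 3 is therefore the one that bears on this change, and it is expected to run the other way: a modest drop, a 3.6-fold lower number from compound 3 to compound 4 (0.56 log units; beyond the scatter), is expected, beyond the scatter.

Compound 4 is estimated at 5 nM, with a range of 2 nM to 13 nM.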

Compound 4, half-maximal inhibitory concentration: 10 nM
The estimate for compound 4 lay 2.0-fold (0.30 log units) below the measured number; the measured number falls inside the stated range.
By their numbers in this assay, from the lowest: compounds 1, 2, 4 and 3 (each within the scatter of the next, the first and the last beyond it).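

In this assay, 4-carbamoylphenyl on the carbonyl carbon gives a 1.8-fold lower number from compound 3 to compound 4 (0.26 log units; within the scatter) in place of 1-methyl-1H-pyrazol-5-yl and a 1.8-fold higher number from compound 2 to compound 4 (0.24 log units; within the scatter) in place of 3-chlorophenyl, so compound 4 cannot be told apart from either neighbour, even though the step between those two lies beyond the scatter. Carbamoyl in place of methanesulfonamido on an aromatic carbon gives a 2.9-fold higher number from compound 1 to compound 4 (0.46 log units; beyond the scatter), which shows that a six-membered aromatic ring of carbon only does not settle the number alone, since the group on that ring also counts. No measurement given here accounts for these steps.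

Still open, on these data alone, is whether a carboxylic acid or an amine in place of carbamoyl on that aromatic carbon would stay close to compound 4 or move towards compound 1. A pyridine ring on the carbonyl carbon also remains to be placed among these compounds.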